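Triazole side-chain exchange on the shared core

The source may report more compounds than this note shows. Statements on the series, on what has been measured and on what is new or still open speak of the compounds shown alone.

Compound 1 `O=C1O[C@H]([C@@H](O)Cn2cc(-c3cccc(O)c3)nn2)C(OCc2ccccc2)=C1OCc1ccccc1` in a functional assay on HepG2 cells (Homo sapiens) for antiproliferative activity, read by MTT assay, with a stated time of 72 h (on this read-out lower numbers stand for stronger inhibition and higher numbers for weaker inhibition), gives 62700 nM. Among the measured compounds shown here, compound 2 `CCCCc1cn(C[C@H](O)[C@H]2OC(=O)C(OCc3ccccc3)=C2OCc2ccccc2)nn1` in this assay gives 32800 nM, the lower of the two numbers so far, although the step of a 1.9-fold lower number from compound 1 to compound 2 (0.28 log units; within the scatter) leaves the two compounds within the scatter of each other. Compound 3 `O=C1O[C@H]([C@@H](O)Cn2cc(CNS(=O)(=O)c3ccc(Cl)cc3F)nn2)C(OCc2ccccc2)=C1OCc1ccccc1` is the next member and carries ((4-chloro-2-fluorophenyl)sulfonyl)amino in place of propyl on a saturated chain carbon bound to an aromatic carbon. Only one measured step exists in this series, the exchange of one group on an aromatic carbon for another, and it stayed within the scatter; no measured step touches a sulfonylamino group on a saturated chain carbon, so the present change has no direct precedent among these compounds. With so little variation seen in this assay, the expectation for compound 3 is a step of a 1.2-fold lower number from compound 2 to compound 3 (0.07 log units; within the scatter) not beyond the scatter, with wide uncertainty. Compound 3 is therefore estimated at 28000 nM, expected range 8000 nM to 90000 nM.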

Compound 3, half-maximal inhibitory concentration: 25500 nM
Estimate against measurement, compound 3: 1.1-fold (0.04 log units) above; the measured number falls inside the stated range.
By their numbers in this assay, from the lowest: compounds 3, 2 and 1 (each within the scatter of the next, the first and the last beyond it).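

In this assay the exchange gives a 1.3-fold lower number from compound 2 to compound 3 (0.11 log units; within the scatter). On a saturated chain carbon bound to an aromatic carbon, propyl with 3 heavy atoms and no ring thus gives way to ((4-chloro-2-fluorophenyl)sulfonyl)amino with 12 heavy atoms, one six-membered aromatic ring, 1 hydrogen-bond donor and 2 hydrogen-bond acceptors, and the two compounds remain within the scatter of each other, so at this place a far larger group with a sulfonylamino link has shown no effect beyond the scatter. No available evidence bears on this result.

Open, going by these compounds, is whether any group at this place moves the number beyond the scatter, for example a primary amine, a carboxylic acid or a longer alkyl chain. Also open, on these data alone, is what an unsubstituted phenylsulfonylamino group or a carboxamide link would give here.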